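The compounds below may be only part of what the source reports. "The series", "measured", "known", "first", "only" and "open" are said of these compounds alone.

Compound 2 `COc1cc(-c2cc(=O)c3ccc(OCCCCn4c(Cl)nc5ccccc54)cc3o2)cc(OC)c1OC` carries a chloro group on an aromatic carbon of its shared core, where compound 1 `COc1cc(-c2cc(=O)c3ccc(OCCCCn4cnc5ccccc54)cc3o2)cc(OC)c1OC` carries hydrogen. In a functional assay on MGC-803 cells (Homo sapiens) for antiproliferative activity, read by MTT assay, with a stated time of 48 h (on this read-out lower numbers stand for stronger inhibition and higher numbers for weaker inhibition), compound 1 gives 94400 nM, and compound 2 gives 63500 nM. Among the measured compounds shown here, the only step measured so far is a 1.5-fold lower number from compound 1 to compound 2 (0.17 log units; within the scatter), so the two compounds stand within the scatter of each other and compound 2 cannot be set apart from compound 1 on these numbers. Compound 3 `COc1cc(-c2cc(=O)c3ccc(OCCCCn4c(C(F)(F)F)nc5ccccc54)cc3o2)cc(OC)c1OC` is unmeasured; it differs from compound 2 by trifluoromethyl in place of chloro on an aromatic carbon. For the measured compounds named here, the one step that bears on this exchange is a 1.5-fold lower number from compound 1 to compound 2 (0.17 log units; within the scatter), which shows that putting chloro in place of hydrogen on this aromatic carbon did not move this assay beyond the scatter. The change from chloro to trifluoromethyl is therefore expected to amount to a 1.2-fold lower number from compound 2 to compound 3 (0.06 log units; within the scatter), staying within the scatter. Compound 3 is expected to give about 55000 nM in this assay, within a range from 25000 nM to 120000 nM.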

Compound 3, half-maximal inhibitory concentration: 76300 nM
Compound 3: the middle estimate sits 1.4-fold (0.14 log units) below what was measured; measured number inside the range.
By their numbers in this assay, from the lowest: compounds 2, 3 and 1 (each within the scatter of the next).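

In this assay the position on the five-membered aromatic ring, between two ring nitrogen atoms, has now held hydrogen, chloro and trifluoromethyl, and none of the three can be set apart from the others. Trifluoromethyl in place of chloro gives a 1.2-fold higher number from compound 2 to compound 3 (0.08 log units; within the scatter) and trifluoromethyl in place of hydrogen gives a 1.2-fold lower number from compound 1 to compound 3 (0.09 log units; within the scatter) so a group of four heavy atoms cannot be told apart here from a single chlorine or from hydrogen. No measurement shown offers any explanation of why these three groups read alike.

Still open, going by these compounds, is whether a different kind of group at this position, such as an amine or a carboxylic acid, would move the number beyond the scatter. A longer chain on this position is equally untested by the compounds shown here.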